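Swapping the ring substituent for a methyl in a rat study

This account rests on a few compounds, and the source may have more. Where it says the series, first, only, none or still open, it means among the compounds named here.

Of the compounds shown here, two sharing one core have so far been tested in a functional assay on the whole organism with Rattus norvegicus as the target, at a dose of 100 mg/kg; on this read-out lower numbers stand for less inhibition and higher numbers for more inhibition at the one dose given (going by the name of the read-out). Compound 1 `C/N=C(/NC#N)NCCCCn1nc(Nc2ccccc2)ccc1=O` carries an anilino group on an aromatic carbon of its core; in this assay compound 1 gives 24.4%. Compound 2 `C/N=C(/NC#N)NCCCCn1nc(N2CCN(C)CC2)ccc1=O` replaces that anilino with 4-methylpiperazin-1-yl, and in this assay compound 2 gives 7.9%, the lower of the two numbers. For the measured compounds named here, the only step measured so far, a number 16.5 percentage points lower from compound 1 to compound 2 (beyond the scatter), lies beyond the scatter.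

Compound 3 `C/N=C(/NC#N)NCCCCn1nc(C)ccc1=O` has not yet been tested. It differs from compound 2 in one place: methyl in place of 4-methylpiperazin-1-yl on an aromatic carbon. Going by the values given here, no measured step exchanges a group for methyl at that carbon, so the single step from compound 1 to compound 2 is the only guide, and it only shows that changing this group can shift the read-out by a modest amount. With that uncertainty, compound 3 is expected to give about 15%, within a range from 0% to 38%. The step this estimate implies, a number 7.1 percentage points higher from compound 2 to compound 3 (within the scatter), is expected to stay within the scatter.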

Compound 3, a percentage reported as inhibition, in the whole organism at one dose (the size of the read-out at that dose, not a potency): 23.5%
Beside the measured number, compound 3's estimate is 8.5 percentage points below it; the range from low to high includes it.
By their numbers in this assay, from the lowest: compound 2; then compounds 3 and 1 (each within the scatter of the next).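

In this assay, for the compounds shown here, the change to methyl gives a number 15.6 percentage points higher from compound 2 to compound 3 (beyond the scatter), so the earlier drop at this aromatic carbon was not a loss that any replacement of the anilino group would bring: the low number so far belongs to 4-methylpiperazin-1-yl alone. The comparison with the anilino compound gives a number 0.9 percentage points lower from compound 1 to compound 3 (within the scatter), so a methyl of 1 heavy atom and no ring cannot be told apart from anilino on this read-out, and a bigger group at this carbon does not simply go with a higher or a lower number among these three compounds. Nothing shown gives a reason for why 4-methylpiperazin-1-yl stands apart from the other two groups.

As far as these compounds go, it remains open whether the lower number comes from the piperazine ring itself or from its methyl, a question that piperazin-1-yl without the methyl, or morpholin-4-yl, would help to settle. Also open, from the compounds shown here alone, is how a primary amine or a carboxylic acid at this carbon would behave, and, with a single dose, whether these numbers would keep their relation at other doses.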